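The source may report more compounds than this note shows. Statements on the series, on what has been measured and on what is new or still open speak of the compounds shown alone.

The measured compounds:
Compound 1 `CC(=O)c1cccc(Nc2ccnc(SCC(=O)c3ccc(-c4ccccc4)cc3)n2)c1` gives 40% in a functional assay on A498 cells (Homo sapiens) for inhibition, read by sulforhodamine B assay, with a stated time of 48 h, tested at 10 uM; on this read-out higher numbers stand for more inhibition of growth at the one concentration tested and lower numbers for less inhibition of growth.
Compound 2 `CC(=O)c1ccc(Nc2ccnc(SCC(=O)c3ccc(Cl)cc3)n2)cc1` gives 19% in this assay.

Among the compounds with values here, of the two numbers known in this assay, compound 1 holds the higher one; compound 2 lies below it by a margin beyond the usual scatter. Compound 2 differs from compound 1 in more than one place, so its lower number cannot be tied to any single exchange.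

Compound 3 `COc1ccc(C(=O)CSc2nccc(Nc3cccc(C(C)=O)c3)n2)cc1` differs from compound 1 in one place: methoxy in place of phenyl on an aromatic carbon, para to a large group. Within the data shown here, no step between measured compounds shows this exchange, so its size has to be guessed. Among the measured compounds shown here, because compound 1 gives 40% and the only other number is lower, the expected step is downward and of moderate size, as a number 15 percentage points lower from compound 1 to compound 3 (beyond the scatter). For compound 3 the estimated value is 25%, with an expected range from 8% to 45%.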

Compound 3, percent growth inhibition at one concentration: 22%
Compound 3: middle estimate off by 3 percentage points, on the high side; the measured number falls inside the stated range.
By their numbers in this assay, from the lowest: compounds 2 and 3 (each within the scatter of the next); then compound 1.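

In this assay, within the data shown here, the exchange of phenyl for methoxy on an aromatic carbon, para to a large group, provides the first step at this position in which only one place changes: a number 18 percentage points lower from compound 1 to compound 3 (beyond the scatter). This shows that the substituent here matters at the one concentration tested, with the rest of the structure held fixed. No measurement shown gives a reason for this step.

Among these compounds, the single exchange removes a six-membered aromatic ring and introduces an oxygen at the same time, so it leaves open which of these changes goes with the lower number. It also leaves open how an amine, a carboxylic acid or a longer alkyl chain at this place would compare with phenyl and methoxy.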